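Chain shortening on the N-benzyl series: estimate for compound 4

A few compounds are considered here, and "the series" means these few. Any claim that something is new, unique, unknown or untested is made for them only; others in the source may bear on it.

Measured so far:
compound 1, `CCCCCCCCCCCCCCCCCC/N=c1\nc(N)c2nc[nH]c2c(N)n1`, 1850 nM
compound 2, `CCCCCCCCCCCCCCCCCC/N=c1\nc(N)c2ncn(Cc3ccccc3)c2c(N)n1`, 5300 nM
compound 3, `CCCCCCCCCCCCCC/N=c1\nc(N)c2ncn(Cc3ccccc3)c2c(N)n1`, 4250 nM

In a functional assay on A549 cells (Homo sapiens) for antiproliferative activity, read by WST assay, with a stated time of 72 h (a higher number here means a weaker inhibitor, a lower number a stronger inhibitor), compound 3 holds the second highest of the three numbers. Compound 2 lies within the scatter of compound 3, so no order between these two is claimed; compound 1 stands beyond the scatter at a lower number. The two measured steps read a 2.9-fold higher number from compound 1 to compound 2 (0.46 log units; beyond the scatter) and a 1.2-fold lower number from compound 2 to compound 3 (0.10 log units; within the scatter).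

Compound 4, `CCCCCCCC/N=c1\nc(N)c2ncn(Cc3ccccc3)c2c(N)n1`, differs from compound 3 in one place: hydrogen in place of hexyl on a saturated chain carbon, eight bonds along the chain from a double-bonded nitrogen. Going by the values given here, the only measured step that bears on this change is a 1.2-fold lower number from compound 2 to compound 3 (0.10 log units; within the scatter), a shortening of the same chain by a smaller amount that stayed within the scatter. Among the compounds with values here, the present cut removes more of the chain, and no measured compound carries a chain as short as that of compound 4, so the outcome is uncertain; a step of about a 1.6-fold higher number from compound 3 to compound 4 (0.22 log units; within the scatter) in this assay is expected, toward a somewhat higher number. In this assay compound 4 is estimated at 7000 nM, with a range from 3000 nM to 20000 nM.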

Compound 4, half-maximal inhibitory concentration: 3830 nM
Estimate against measurement, compound 4: 1.8-fold (0.26 log units) above; measured number inside the range.
By their numbers in this assay, from the lowest: compound 1; then compounds 4, 3 and 2 (each within the scatter of the next).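

In this assay the cut of hexyl gives a 1.1-fold lower number from compound 3 to compound 4 (0.05 log units; within the scatter) and the longer cut of decyl at the same place gives a 1.4-fold lower number from compound 2 to compound 4 (0.14 log units; within the scatter), so both lie within the scatter. Compound 2, compound 3 and compound 4 therefore cannot be ordered, and on the benzyl series this place tolerates a wider shortening of the chain than the earlier step covered, with no readable shift in the number. Nothing at hand gives a reason for this flat reading.

Chains shorter than that of compound 4, such as butyl, remain open, as does a chain ending in an amine or a carboxylic acid. Also open, as far as these compounds go, is whether a 2.9-fold higher number from compound 1 to compound 2 (0.46 log units; beyond the scatter) on adding benzyl holds at shorter chains, since compound 1 alone carries hydrogen on that aromatic nitrogen.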